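Trimming an aryl ring down to methyl on the shared core

The source may report more compounds than this note shows. Statements on the series, on what has been measured and on what is new or still open speak of the compounds shown alone.

Within the data shown here, compound 2 `Fc1ccc(Cl)c(-c2cc(-c3cnn(C4CCNCC4)c3)on2)c1` gives 29% in an assay on a protein complex for positive allosteric modulation of Neuronal acetylcholine receptor; alpha4/beta2 (Homo sapiens) (on this read-out lower numbers stand for smaller maximal responses and higher numbers for larger maximal responses), the lower of the two numbers measured so far. Compound 1 `Cc1c(-c2cc(-c3ccccc3Cl)no2)cnn1C1CCNCC1` gives 71% in this assay, a gap beyond the scatter. Compound 3 `Cc1cc(-c2cnn(C3CCNCC3)c2)on1` is not yet measured; it differs from compound 2 in one place: methyl in place of 2-chloro-5-fluorophenyl on an aromatic carbon. Among the measured compounds shown here, no measured pair shows this change, so its effect is unknown. A step in this assay of modest size upward is expected from compound 2 to compound 3, a number 11 percentage points higher from compound 2 to compound 3 (beyond the scatter), though the direction is uncertain. Compound 3 is expected to give about 40%, within a wide range from 10% to 80%.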

Compound 3, largest response reached (reported as efficacy), in percent of the reference or control that the assay uses: 19%
Compound 3: the middle estimate sits 21 percentage points above what was measured, within the range that was stated.
By their numbers in this assay, from the lowest: compounds 3 and 2 (each within the scatter of the next); then compound 1.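

In this assay the swap of 2-chloro-5-fluorophenyl for methyl at this position gives a number 10 percentage points lower from compound 2 to compound 3 (within the scatter) and so the two compounds cannot be told apart on this read-out. At this aromatic carbon, then, a group of 8 heavy atoms with its aromatic ring and a single carbon give matching maximal responses. Nothing available explains this match. On these data alone, what stays open is whether any other group here, such as an amine, a carboxylic acid or a longer chain, would move the response beyond the scatter.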